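Phenyl Added to the Core of a Benzamide Series

A few compounds are considered here, and "the series" means these few. Any claim that something is new, unique, unknown or untested is made for them only; others in the source may bear on it.

Measured compounds:
compound 1, `O=C(Nc1nccn2cc(-c3ccccc3)nc12)c1ccccc1`, 18%
compound 2, `COc1ccc(-c2cn3ccnc(NC(=O)c4ccccc4)c3n2)cc1`, 1%

In an assay on cells for displacement of a labelled ligand from adenosine receptor A1 (Homo sapiens), read by scintillation counting, with a stated time of 120 min, tested at 1 uM (a higher number here means more inhibition at the concentration tested (going by the name of the read-out), a lower number less inhibition), compound 1 gives 18%. Compound 2 is the methoxy analogue, and in this assay compound 2 gives 1%, the lowest of the two numbers available, lying a number 17 percentage points lower from compound 1 to compound 2 (beyond the scatter).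

Compound 3, `COc1ccc(-c2cn3cc(-c4ccccc4)nc(NC(=O)c4ccccc4)c3n2)cc1`, has not been measured in this assay. It differs from compound 2 in one place: phenyl in place of hydrogen on an aromatic carbon.

Among the measured compounds shown here, no measured step in this set bears on this change. For the measured compounds named here, the only step available, a number 17 percentage points lower from compound 1 to compound 2 (beyond the scatter), concerns a methoxy in place of hydrogen on an aromatic carbon, not a phenyl on the core. There is therefore nothing to say how the new phenyl will act, and the baseline of compound 2 already sits near the bottom of the scale. The step from compound 2 to compound 3 is expected to be small, a number 9 percentage points higher from compound 2 to compound 3 (within the scatter), within or barely beyond the scatter. For compound 3 the estimate in this assay is 10%, with a range from 0% to 30%.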

Compound 3, a percentage reported as inhibition, at one concentration (the size of the read-out at that concentration, not a potency): 3%
The estimate for compound 3 lay 7 percentage points above the measured number; the measured number falls inside the stated range.
By their numbers in this assay, from the lowest: compounds 2 and 3 (each within the scatter of the next); then compound 1.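

In this assay, among the compounds shown here, the first reading at this carbon of the core, next to the ring nitrogen and meta to a benzamido group, shows no difference that can be told from the scatter when phenyl stands in place of hydrogen: a number 2 percentage points higher from compound 2 to compound 3 (within the scatter). The earlier step concerned only a methoxy on the outer aromatic ring and said nothing about this position, whereas this pair shows that a whole aromatic ring of six carbon atoms can be placed here without a readable change in the number, although the reading of compound 2 at 1% already lies so low that a further fall could hardly be seen. Nothing available here explains this result.

Going by these compounds, it remains open whether the same phenyl would leave the number unchanged on compound 1, which gives 18% and so has room to fall as well as to rise. On these data alone, it is equally open whether an amine, a carboxylic acid or a longer alkyl chain on this same carbon would give a reading clearly different from that of compound 2.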